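The compounds below may be only part of what the source reports. "The series", "measured", "known", "first", "only" and "open" are said of these compounds alone.

Compound 1, with the structure `O=C(NCc1ccc(F)cc1)c1cc(Oc2ccc(/C=C/c3ccccn3)cc2)ccn1`, anchors this small series. In a functional assay on A549 cells (Homo sapiens) for antiproliferative activity, read by CCK-8 assay, with a stated time of 48 h (on this read-out lower numbers stand for stronger inhibition and higher numbers for weaker inhibition), compound 1 gives only a limit, > 100000 nM, and no number. Compound 2, `CC(C)NC(=O)c1cc(Oc2ccc(/C=C/c3ccccn3)cc2)ccn1`, carries an isopropyl group in place of the 4-fluorobenzyl group, the difference counted as isopropyl in place of 4-fluorobenzyl on an amide-type nitrogen; in this assay compound 2 gives 21400 nM. The step from compound 1 to compound 2 is an at least 4.6-fold lower number from compound 1 to compound 2 (0.66 log units; beyond the scatter), and its true size is open at one end because the limit of > 100000 nM in this assay, at which 1 of the 3 values shown sits, fixes only where compound 1 stops being measurable. Compound 3, `O=C(NCc1ccc(F)cc1)c1cc(Oc2ccc(/C=C/c3ccncc3)cc2)ccn1`, keeps the 4-fluorobenzyl amide of compound 1 but differs in its core, the two having the same atoms joined differently, as counted in pyridin-4-yl in place of pyridin-2-yl on a double-bonded chain carbon bound to a double-bonded chain carbon; in this assay compound 3 gives 18200 nM, and the step from compound 1 to compound 3 is an at least 5.4-fold lower number from compound 1 to compound 3 (0.73 log units; beyond the scatter). Compound 2 and compound 3 sit within the scatter of each other.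

Compound 4, `CC(C)NC(=O)c1cc(Oc2ccc(/C=C/c3ccncc3)cc2)ccn1`, has not yet been measured. It relates to compound 3 as compound 2 relates to compound 1: isopropyl in place of 4-fluorobenzyl on an amide-type nitrogen. The place is the same in both cases, so this is the same change, made here on the core of compound 3 rather than that of compound 1. Since the earlier instance, an at least 4.6-fold lower number from compound 1 to compound 2 (0.66 log units; beyond the scatter), started from a limit, only its smallest size is known. The step from compound 3 to compound 4 is expected to be a 2.3-fold lower number from compound 3 to compound 4 (0.36 log units; beyond the scatter), somewhat smaller than a simple repeat might suggest, since compound 3 already stands at 18200 nM. Compound 4 is therefore estimated at 8000 nM in this assay, with a likely range from 2500 nM to 30000 nM.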

Compound 4, half-maximal inhibitory concentration: 20600 nM
For compound 4 the middle estimate is 2.6-fold (0.41 log units) below the measured one, and the stated range covers the measured number.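

In this assay, isopropyl in place of 4-fluorobenzyl on an amide-type nitrogen gives a 1.1-fold higher number from compound 3 to compound 4 (0.05 log units; within the scatter), so this change does not carry over unchanged from the core of compound 1 to the core of compound 3: the same change on two cores in this assay, an at least 4.6-fold lower number (0.66 log units; beyond the scatter) from compound 1 to compound 2 and a 1.1-fold higher number (0.05 log units; within the scatter) from compound 3 to compound 4, at least 5.2-fold (0.72 log units) apart, beyond the scatter of two such steps. The same holds for the other change, pyridin-4-yl in place of pyridin-2-yl, which with the isopropyl amide in place gives a 1.0-fold lower number from compound 2 to compound 4 (0.02 log units; within the scatter): the same change on two cores in this assay, an at least 5.4-fold lower number (0.73 log units; beyond the scatter) from compound 1 to compound 3 and a 1.0-fold lower number (0.02 log units; within the scatter) from compound 2 to compound 4, at least 5.2-fold (0.72 log units) apart, beyond the scatter of two such steps. Both gaps are known only as smallest sizes, since compound 1 gives a limit and no number, and these four compounds show that the two changes do not add up here, but not how either would behave on any further core: the limit of > 100000 nM in this assay, at which 1 of the 4 values shown sits.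

The compounds shown leave open whether a pyridin-3-yl group on the double-bonded chain would follow the pyridin-2-yl or the pyridin-4-yl compounds. They also leave open whether other groups on the amide nitrogen, such as a cyclopropyl group, a longer alkyl chain or an unsubstituted benzyl group, would separate the two cores or leave them as close as compound 2 and compound 4 are.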